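The source may report more compounds than this note shows. Statements on the series, on what has been measured and on what is new or still open speak of the compounds shown alone.

Compound 1, `Cc1nnc(SCc2cc(=O)c3ccccc3o2)o1`, is examined in a functional assay on MDA-MB-435S cells (Homo sapiens) for cytotoxicity, read by MTT assay, with a stated time of 72 h; on this read-out higher numbers stand for weaker inhibition and lower numbers for stronger inhibition. In this assay compound 1 reaches only the limit of the assay, > 25000 nM. Compound 2, `Cc1cc(C)n2nc(SCc3nnc(SCc4cc(=O)c5ccccc5o4)s3)nc2n1`, shares the core of compound 1. In this assay compound 2 likewise gives only a limit, > 25000 nM. Both measured values sit at the limit of > 25000 nM in this assay, at which 2 of the 2 values shown sit, so compound 1 stands at that edge with nothing measured beneath it for comparison. Compound 3, `Cc1nnc(SCc2cc(=O)c3cc(Cl)ccc3o2)o1`, differs from compound 1 in one place: chloro in place of hydrogen on an aromatic carbon. For the measured compounds named here, no measured pair shows what such a change does here. In this assay the expected step is an at least 1.1-fold lower number from compound 1 to compound 3 (0.05 log units; that floor lies within the scatter), a shift not expected to go beyond the usual scatter. Compound 3 is therefore expected to give about 22000 nM, between 6000 nM and 60000 nM, in this assay, most likely again reported only as a limit.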

Compound 3, half-maximal inhibitory concentration: > 25000 nM
Compound 3: no number, only a limit (the forecaster's own chance of this, stated with the estimate: 65%); middle value at least 1.1-fold (0.05 log units) away from the limit.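

Compound 1 and compound 3 each give only a limit, so no step between them can be read: the limit of > 25000 nM in this assay, at which 3 of the 3 values shown sit.

The compounds shown leave open what chloro in place of hydrogen does in this assay, and which changes to the shared core would give a measurable number.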